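The compounds below may be only part of what the source reports. "The series", "measured", "known", "first", "only" and "open" are said of these compounds alone.

Measured so far in an ADME assay on HepG2 cells (Homo sapiens) for cytotoxicity, read by luminescence, CellTiter-Glo and ATP content, with a stated time of 72 h; on this read-out higher numbers stand for an effect only at larger amounts of compound and lower numbers for an effect already at smaller amounts:
compound 1 `COc1ccc(-c2ccc3c(NCCCNCc4cccc(OC)c4O)ccnc3c2)cc1` gives 1600 nM
compound 2 `COc1ccc(F)cc1CNCCCNc1ccnc2cc(Oc3ccc(F)cc3)ccc12` gives 6600 nM
compound 3 `COc1cccc(CNCCCNc2ccnc3cc(Oc4ccc(F)cc4)ccc23)c1O` gives 11000 nM

Compound 2 stands second highest of the three numbers. For the measured compounds named here, its nearest neighbour is compound 3, reached by a 1.7-fold higher number from compound 2 to compound 3 (0.22 log units; within the scatter); its furthest is compound 1, which lies below it by a gap beyond the scatter, though no single-place step connects those two. The unmeasured compound 4 `COc1ccc(F)cc1CNCCCNc1ccnc2cc(Cc3ccc(F)cc3)ccc12` differs from compound 2 in one place: 4-fluorobenzyl in place of 4-fluorophenoxy on an aromatic carbon.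

Going by the values given here, only one measured step touches that position on the core: a 6.9-fold higher number from compound 1 to compound 3 (0.84 log units; beyond the scatter), where one ring was exchanged for another at the same place and the number moved by a modest amount. That step, however, changes the ring itself, whereas the change to compound 4 keeps the ring and alters only its link to the core, so it is a loose guide at best. The step of a 1.7-fold higher number from compound 2 to compound 3 (0.22 log units; within the scatter) concerns the other end of the chain and does not bear on this change. Among the compounds with values here, the direction is therefore open; a shift of the size seen in the one relevant step could go either way, and the central expectation is no movement beyond the scatter. Compound 4 is estimated at 5000 nM, with a range from 1500 nM to 16000 nM, which corresponds to an expected step of a 1.3-fold lower number from compound 2 to compound 4 (0.12 log units; within the scatter).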

Compound 4, half-maximal effective concentration: 3530 nM
Estimate against measurement, compound 4: 1.4-fold (0.15 log units) above; the range from low to high includes it.
By their numbers in this assay, from the lowest: compound 1; then compounds 4, 2 and 3 (each within the scatter of the next, the first and the last beyond it).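

In this assay, for the compounds shown here, 4-fluorobenzyl in place of 4-fluorophenoxy on this aromatic carbon stays within the scatter (a 1.9-fold lower number from compound 2 to compound 4 (0.27 log units; within the scatter)), giving the first reading of a change that keeps the ring and alters only its link to the shared core. Going by these compounds alone, the only earlier step at this carbon, which exchanged 4-methoxyphenyl for 4-fluorophenoxy, lies beyond the scatter (a 6.9-fold higher number from compound 1 to compound 3 (0.84 log units; beyond the scatter)), so at this carbon the one step that changes the link alone is the one that stays within the scatter, although the two steps carry different groups at the far end of the chain. No measured evidence bears on why the number behaves this way at this place.

Within the data shown here, it remains open whether the same exchange also stays within the scatter in compounds carrying 2-hydroxy-3-methoxyphenyl at the far end of the chain, as compound 3 does, since the single step here comes from the 5-fluoro-2-methoxyphenyl series alone. Also open, going by these compounds, is how the number responds to other links at this carbon, such as an amine, a carbonyl or a longer chain such as 2-(4-fluorophenyl)ethyl.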